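The source may report more compounds than this note shows. Statements on the series, on what has been measured and on what is new or still open speak of the compounds shown alone.

Measured so far in an assay on CHO cells for agonist activity at Neuronal acetylcholine receptor; alpha3/alpha6/beta2/beta3 (Homo sapiens), read by FLIPR and calcium flux; on this read-out lower numbers stand for an effect already at smaller amounts and higher numbers for an effect only at larger amounts of compound:
compound 1 `CC(=O)N1CC2CC(C1)N2`: 750 nM
compound 2 `O=C([C@H]1C[C@H]1F)N1CC2CC(C1)N2`: 62 nM
compound 3 `C[C@@H]1C[C@@H]1C(=O)N1CC2CC(C1)N2`: 920 nM

Compound 3 has the highest number of the three; compound 1 is within the scatter of it, as a 1.2-fold higher number from compound 1 to compound 3 (0.09 log units; within the scatter) shows, while compound 2 lies well apart, as a 15-fold higher number from compound 2 to compound 3 (1.17 log units; beyond the scatter) shows. Compound 4 `C[C@H]1C[C@H]1C(=O)N1CC2CC(C1)N2` is the mirror image of compound 3: the two compounds have the same atoms and bonds; at least one stereo element is drawn with a configuration in one of them and without one in the other: 2 of 4 stereo elements differ; a stereocentre at a saturated ring carbon is drawn R in compound 3 and S in compound 4; a stereocentre at a saturated ring carbon is drawn S in compound 3 and R in compound 4. Among the measured compounds shown here, no measured step inverts stereocentres, so none of the steps bears directly on this change. The steps that touch the same position, a 12-fold lower number from compound 1 to compound 2 (1.08 log units; beyond the scatter) and a 15-fold higher number from compound 2 to compound 3 (1.17 log units; beyond the scatter), only show that what sits on the carbonyl carbon can move this assay by a large amount, and that compound 2 reaches a low number with a small group on the three-membered ring. The account therefore expects compound 4 to sit lower than compound 3 by a 2.3-fold lower number from compound 3 to compound 4 (0.36 log units; beyond the scatter) in this assay, with wide uncertainty. Compound 4 is estimated at 400 nM, in the range 80 nM to 2000 nM.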

Compound 4, half-maximal effective concentration: 2000 nM
Compound 4: middle estimate off by 5.0-fold (0.70 log units), on the low side; the range from low to high includes it.
By their numbers in this assay, from the lowest: compound 2; then compounds 1 and 3 (each within the scatter of the next); then compound 4.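

In this assay, the configuration of the 2-methylcyclopropyl group on the carbonyl carbon matters in its own right: with atoms and bonds the same, the change gives a 2.2-fold higher number from compound 3 to compound 4 (0.34 log units; beyond the scatter). Replacing methyl with this group can now also be seen to have an effect, with a 2.7-fold higher number from compound 1 to compound 4 (0.43 log units; beyond the scatter), whereas compound 3 stands within the scatter of compound 1, so the outcome of that replacement depends on the configuration. The inverted methyl-bearing ring also stays far from the fluoro-bearing ring, at a 32-fold higher number from compound 2 to compound 4 (1.51 log units; beyond the scatter).

How firmly the modest step can be tied to a specific configuration remains limited by one point in the drawings: the fact that one of compounds 3 and 4 is drawn with a defined configuration and the other without, at the place where they differ. From the compounds shown here alone, whether the mirror image of the 2-fluorocyclopropyl group, or a 2-chlorocyclopropyl group, would show a similar dependence on configuration remains open.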